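Amino substituent variation on the shared core

The source may report more compounds than this note shows. Statements on the series, on what has been measured and on what is new or still open speak of the compounds shown alone.

Among the measured compounds shown here, compound 2 `CCCN(C)c1nc(N)c(C(=O)N=C(N)N)nc1Cl` gives 91% in an assay for inhibition of acid-sensing ion channel 3 (Homo sapiens), read by patch clamp, tested at 20 uM (a lower number here means less inhibition, a higher number more inhibition at the concentration tested (going by the name of the read-out)), the highest of the two numbers measured so far. Compound 1 `CC(C)(C)Nc1nc(N)c(C(=O)N=C(N)N)nc1Cl` gives 48% in this assay, and the step of a number 43 percentage points higher from compound 1 to compound 2 (beyond the scatter) shows that the substituent on this aromatic carbon moves the read-out strongly. Compound 3 `CN1CCN(c2nc(N)c(C(=O)N=C(N)N)nc2Cl)CC1` is the next variation at the same place: 4-methylpiperazin-1-yl in place of methyl(propyl)amino on an aromatic carbon. For the measured compounds named here, only the step of a number 43 percentage points higher from compound 1 to compound 2 (beyond the scatter) bears on this change, and it was large; nothing measured shows what 4-methylpiperazin-1-yl itself does here, so the direction is uncertain and a wide range is kept. Compound 3 is expected to give 60% in this assay, between 30% and 90%. The expected step of a number 31 percentage points lower from compound 2 to compound 3 (beyond the scatter) is a moderate fall, since compound 2 sits high at 91% and leaves little room upward.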

Compound 3, a percentage reported as inhibition, at one concentration (the size of the read-out at that concentration, not a potency): 51%
Beside the measured number, compound 3's estimate is 9 percentage points above it, and the stated range covers the measured number.
By their numbers in this assay, from the lowest: compounds 1 and 3 (each within the scatter of the next); then compound 2.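

In this assay, the step of a number 40 percentage points lower from compound 2 to compound 3 (beyond the scatter) shows that the high read-out of compound 2 does not carry over when 4-methylpiperazin-1-yl replaces methyl(propyl)amino on this aromatic carbon. The step of a number 3 percentage points higher from compound 1 to compound 3 (within the scatter) leaves 4-methylpiperazin-1-yl and (tert-butyl)amino indistinguishable here, so among these three groups only methyl(propyl)amino stands apart. No available evidence accounts for these differences at this position.

Open, from the compounds shown here alone, is whether the higher number of compound 2 rests on the methyl or on the propyl chain of its amine, which propylamino and dimethylamino at this place would separate. Also open, going by these compounds, is whether the lower number of compound 3 goes with the ring itself or with its second nitrogen, a question that piperidin-1-yl and morpholin-4-yl would address.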